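Thiosemicarbazones of a monoterpene isothiocyanate in a melanoma cell assay

The source may report more compounds than this note shows. Statements on the series, on what has been measured and on what is new or still open speak of the compounds shown alone.

Measured compounds:
- compound 1 `CC1=CC[C@H](C(C)(C)N=C=S)CC1`: "not determined" (no result reported)
- compound 2 `CC1=CC[C@H](C(C)(C)NC(=S)N/N=C/c2ccccc2O)CC1`: 2800 nM

Compound 1 `CC1=CC[C@H](C(C)(C)N=C=S)CC1` carries the isothiocyanate from which the thiosemicarbazones are built; in a functional assay on UACC-62 cells (Homo sapiens) for inhibition, read by sulforhodamine B assay, with a stated time of 48 h (a lower number here means a stronger inhibitor of growth, a higher number a weaker inhibitor of growth), compound 1 has "not determined" (no result reported), no reported result. Among the compounds with values here, compound 2 `CC1=CC[C@H](C(C)(C)NC(=S)N/N=C/c2ccccc2O)CC1` is the only compound with a number here: in this assay compound 2 gives 2800 nM, so it stands alone, with nothing to rank it against.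

Compound 3 `CC1=CC[C@H](C(C)(C)NC(=S)N/N=C/c2ccc(Cl)cc2)CC1` differs from compound 2 in one place: 4-chlorophenyl in place of 2-hydroxyphenyl on a carbon with a double bond to nitrogen. Within the data shown here, no measured pair shows what such an exchange does in this assay, so the direction of the step cannot be read from the data. Since the change leaves the shared core untouched, the step is expected to stay within or only slightly beyond the scatter, and compound 3 is expected at 3500 nM (range 1000 nM to 12000 nM), which means an expected step of a 1.3-fold higher number from compound 2 to compound 3 (0.10 log units; within the scatter).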

Compound 3, concentration for 50% growth inhibition: 11200 nM
For compound 3 the middle estimate is 3.2-fold (0.51 log units) below the measured one; the measured number falls inside the stated range.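

In this assay the place on a carbon with a double bond to nitrogen now has its first measured exchange: 4-chlorophenyl in place of 2-hydroxyphenyl gives a 4.0-fold higher number from compound 2 to compound 3 (0.60 log units; beyond the scatter) and so moves growth inhibition beyond the scatter. The group at this place therefore matters in this series, and the 2-hydroxyphenyl of compound 2 is the better of the two. The exchange removes the oxygen and adds a chlorine in a single step, so this one pair cannot separate the two changes, and nothing at hand explains the step.

The compounds shown leave open whether the loss of the oxygen or the arrival of the chlorine carries the step. An unsubstituted phenyl or a pyridine ring at this place would help to separate the two.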